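The compounds below may be only part of what the source reports. "The series", "measured", "known", "first", "only" and "open" are said of these compounds alone.

Compound 2 `Cc1cnc(Nc2ccc(C(=O)Nc3c(C)cccc3C)cc2)nc1-c1cccc(OC(F)(F)F)c1` and compound 3 `Cc1cnc(Nc2ccc(C(=O)Nc3c(C)cccc3C)cc2)nc1-c1ccccc1OC(F)(F)F` share one core and differ only in the trifluoromethoxyphenyl group attached to it. In an assay on NIH3T3 cells for inhibition of Sonic hedgehog protein (Mus musculus), read by a luciferase reporter, with a stated time of 48 h (a lower number here means a stronger inhibitor, a higher number a weaker inhibitor), compound 2 gives 1.2 nM. Compound 3 gives only a limit of this assay, > 500 nM. Compound 1 `Cc1cnc(Nc2ccc(N3C[C@@H](C)O[C@@H](C)C3)nc2)nc1-c1ccc(OC(F)(F)F)cc1`, which carries a different amine side, likewise gives only a limit in this assay, > 500 nM, in keeping with the limit of > 500 nM in this assay, at which 2 of the 3 values shown sit. Compound 4 `Cc1cnc(Nc2ccc(C(=O)Nc3c(C)cccc3C)cc2)nc1-c1ccc(C#N)cc1` has not yet been measured; it differs from compound 3 by 4-cyanophenyl in place of 2-(trifluoromethoxy)phenyl on an aromatic carbon. Among the compounds with values here, the one measured step that bears on this change is an at least 410-fold higher number from compound 2 to compound 3 (2.61 log units; beyond the scatter), a large loss tied to the 2-(trifluoromethoxy)phenyl that compound 4 gives up. Within the data shown here, a gain is therefore expected, though no measured compound carries a 4-cyanophenyl, so its size is uncertain. Compound 4 is estimated at 30 nM, between 3 nM and 500 nM, an expected step of an at least 16-fold lower number from compound 3 to compound 4 (1.22 log units; beyond the scatter).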

Compound 4, half-maximal inhibitory concentration: 2.8 nM
Compound 4: the middle estimate sits 11-fold (1.03 log units) above what was measured, outside the stated range (below it).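

Compound 4 shows that this position does not need a trifluoromethoxy group for strong inhibition: 4-cyanophenyl brings an at least 170-fold lower number from compound 3 to compound 4 (2.25 log units; beyond the scatter). Measured against the other strong compound, the same group gives only a modest change, a 2.3-fold higher number from compound 2 to compound 4 (0.37 log units; beyond the scatter). The first step has no exact size, as compound 3 gives only a limit of the assay: the limit of > 500 nM in this assay, at which 2 of the 4 values shown sit.

Going by these compounds, it remains open whether the nitrile itself or its placement on the phenyl matters, which 2-cyanophenyl and 3-cyanophenyl would test. On these data alone, whether 4-aminophenyl or 4-carboxyphenyl would also hold this strength is unknown too.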